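Removing the Nitrile and Fluorine from the Aryl Group

This account rests on a few compounds, and the source may have more. Where it says the series, first, only, none or still open, it means among the compounds named here.

Measured compounds:
- compound 1, `O=C(O)Cc1sc(COc2ccc(Cl)cc2)nc1-c1ccc(Cl)cc1`, 32 nM
- compound 2, `N#Cc1cc(-c2nc(C(c3ccc(F)cc3)c3ccc(F)cc3)sc2CC(=O)O)ccc1F`, 57 nM
- compound 3, `O=C(O)Cc1sc(C(c2ccccc2)c2ccccc2)nc1-c1ccccc1`, 570 nM

In an in vitro assay on HEK385-7 cells for displacement of a labelled ligand from prostaglandin D2 receptor 2 (Homo sapiens) (a higher number here means a weaker inhibitor, a lower number a stronger inhibitor), compound 2 gives 57 nM, the second highest of the three numbers. Compound 1 gives 32 nM, which lies within the scatter of compound 2, so the two cannot be ranked. Compound 3 gives 570 nM, a number beyond the scatter and clearly weaker than compound 2.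

Compound 4, `O=C(O)Cc1sc(C(c2ccc(F)cc2)c2ccc(F)cc2)nc1-c1ccccc1`, has not yet been measured. It differs from compound 2 in one place: phenyl in place of 3-cyano-4-fluorophenyl on an aromatic carbon. Compound 3 also carries a plain phenyl on the shared core, and it is the weakest of the three measured compounds. For the measured compounds named here, no step between two measured compounds isolates this exact change, so the expectation rests on what the values show: compound 2 is strong, compound 3, with phenyl instead of the substituted aryl, is weaker.

The step from compound 2 to compound 4 is therefore expected to weaken inhibition, by a 5.3-fold higher number from compound 2 to compound 4 (0.72 log units; beyond the scatter), beyond the scatter. Compound 4 is estimated at 300 nM, with a likely range from 100 nM to 900 nM.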

Compound 4, half-maximal inhibitory concentration: 16 nM
Beside the measured number, compound 4's estimate is 19-fold (1.27 log units) above it; measured number outside the range, below it.
By their numbers in this assay, from the lowest: compounds 4, 1 and 2 (each within the scatter of the next, the first and the last beyond it); then compound 3.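

In this assay, putting phenyl in place of 3-cyano-4-fluorophenyl on the aromatic carbon next to the ring nitrogen gives a 3.6-fold lower number from compound 2 to compound 4 (0.55 log units; beyond the scatter). For the compounds shown here, this is the first change that can be read at a single position, and it shows that the nitrile and the fluorine on this aryl group are not needed for strong inhibition: the smaller phenyl, which has no hydrogen-bond acceptor, gives a modestly lower number, not a higher one. Nothing measured here explains why the plain phenyl does better in this pair.

The nitrile and the fluorine leave together, so this step cannot say whether one of them or both lie behind the difference; a 4-fluorophenyl or a 3-cyanophenyl at this position would separate the two. Also open, going by these compounds, is whether a methoxy group or an amine on this phenyl would lower the number further or raise it again, and whether the same swap would behave alike on a different group at the other positions of the shared core.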